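This account rests on a few compounds, and the source may have more. Where it says the series, first, only, none or still open, it means among the compounds named here.

Measured in a functional assay on HCT-116 cells (Homo sapiens) for cytotoxicity, read by MTT assay, with a stated time of 48 h; on this read-out higher numbers stand for weaker inhibition and lower numbers for stronger inhibition:
- compound 1 `COc1cc(/C=C/C(=O)C2=C(/C=C/c3ccc(O)c(OC)c3)NC(=O)NC2c2ccc(C)cc2)ccc1O`: 12500 nM
- compound 2 `COc1cc(/C=C/C(=O)C2=C(/C=C/c3ccc(O)c(OC)c3)NC(=O)NC2c2ccccc2O)ccc1O`: 100000 nM

Compound 2 holds the higher of the two numbers. Compound 3 `COc1cc(/C=C/C(=O)C2=C(/C=C/c3ccc(O)c(OC)c3)NC(=O)NC2c2ccc(O)cc2)ccc1O` has 4-hydroxyphenyl in place of 2-hydroxyphenyl on a saturated ring carbon. For the measured compounds named here, only one measured step bears on this change, at the same ring carbon: an 8.0-fold higher number from compound 1 to compound 2 (0.90 log units; beyond the scatter), modest and beyond the scatter. On these data alone, with the 2-hydroxyphenyl group gone, a partial return towards compound 1 at 12500 nM is expected, though a hydroxyl at the 4-position remains untested. The expected change is a 3.3-fold lower number from compound 2 to compound 3 (0.52 log units; beyond the scatter), a modest move to a lower number. For compound 3 the estimated value is 30000 nM, with an expected range of 9000 nM to 100000 nM.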

Compound 3, half-maximal inhibitory concentration: 100000 nM
Beside the measured number, compound 3's estimate is 3.3-fold (0.52 log units) below it; measured number inside the range.
By their numbers in this assay, from the lowest: compound 1; then compounds 2 and 3 (each within the scatter of the next).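

In this assay, 4-hydroxyphenyl and 2-hydroxyphenyl on this saturated ring carbon show no change at the digits printed from compound 2 to compound 3 (within the scatter), so among these compounds the hydroxyl's ring position makes no difference. Hydroxy in place of methyl on the aromatic carbon gives an 8.0-fold higher number from compound 1 to compound 3 (0.90 log units; beyond the scatter), which places compound 3 with compound 2 and leaves 4-methylphenyl as the better group at this position. Nothing on hand explains this difference.

Whether the methyl itself matters remains open, since plain phenyl is not among the compounds shown. Methoxy, chloro or an amine at the 4-position also remain to be compared with compound 1.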